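Thiomorpholine to morpholine swap on a thiosemicarbazide series

This account rests on a few compounds, and the source may have more. Where it says the series, first, only, none or still open, it means among the compounds named here.

Measured so far in a functional assay on HeLa cells (Homo sapiens) for cytotoxicity, read by MTT assay, with a stated time of 72 h; on this read-out lower numbers stand for stronger inhibition and higher numbers for weaker inhibition:
compound 1 `Cc1ccnc(/C(N)=N/NC(=S)N2CCOCC2)c1` gives 38500 nM
compound 2 `Cc1cccc(/C(N)=N/NC(=S)N2CCSCC2)n1` gives 1800 nM
compound 3 `Cc1ccnc(/C(N)=N/NC(=S)N2CCSCC2)c1` gives 15500 nM

Compound 2 holds the lowest number of the three. Compound 2 and compound 3 have the same atoms joined differently; the difference between the two cores is not broken down here, and what the two values show is that compound 2 stands well below compound 3 in this assay.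

One change is measured directly: morpholin-4-yl in place of thiomorpholin-4-yl on a thiocarbonyl carbon. This step, a 2.5-fold higher number from compound 3 to compound 1 (0.40 log units; beyond the scatter), is modest but sits beyond the scatter.

Compound 4 `Cc1cccc(/C(N)=N/NC(=S)N2CCOCC2)n1` is not yet measured. Relative to compound 2 the change is morpholin-4-yl in place of thiomorpholin-4-yl on a thiocarbonyl carbon. Among the compounds with values here, the place around the change reads the same for both pairs, so this is the same change as the one from compound 3 to compound 1, made on the core of compound 2 instead of the core of compound 3.

Within the data shown here, with only one measured example of the change, the expectation for compound 4 rests on that single step. The step from compound 2 to compound 4 is expected to be of the same kind and size, a 2.5-fold higher number from compound 2 to compound 4 (0.40 log units; beyond the scatter), because the measured change gave a 2.5-fold higher number from compound 3 to compound 1 (0.40 log units; beyond the scatter).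

Compound 4 is therefore expected to give about 4500 nM in this assay.

On these data alone, compound 4 is estimated to fall between 2000 nM and 12000 nM, the width reflecting that the transfer to a different core is untested.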

Compound 4, half-maximal inhibitory concentration: 2200 nM
For compound 4 the middle estimate is 2.0-fold (0.31 log units) above the measured one; low and high end bracket the measured number.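

In this assay, morpholin-4-yl in place of thiomorpholin-4-yl on a thiocarbonyl carbon gives a 1.2-fold higher number from compound 2 to compound 4 (0.09 log units; within the scatter). Set beside the step measured on the core of compound 3, this new step cannot be told apart from it: the same change on two cores in this assay, a 2.5-fold higher number (0.40 log units; beyond the scatter) from compound 3 to compound 1 and a 1.2-fold higher number (0.09 log units; within the scatter) from compound 2 to compound 4, 2.0-fold (0.31 log units) apart, within the scatter of two such steps The change therefore carries across these two cores without a detectable difference in size, even though only the step on the core of compound 3 lies beyond the scatter; this does not show that the two steps are identical, and one pair on each of two cores gives no rule for the wider series.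

Still open, on these data alone, is whether the near-equal reading of the two rings on the core of compound 2 extends to other groups on the thiocarbonyl carbon, such as piperidin-1-yl, 4-methylpiperazin-1-yl or an open-chain dimethylamino group. Also open is whether the same step would appear on a further core, or in any cell line other than the one used here, as all four compounds shown are compared in this single cytotoxicity read-out.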